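This account rests on a few compounds, and the source may have more. Where it says the series, first, only, none or still open, it means among the compounds named here.

Measured compounds and their numbers in an assay on cells for displacement of a labelled ligand from corticotropin-releasing factor receptor 1 (Homo sapiens), with a stated time of 100 min; on this read-out lower numbers stand for stronger inhibition and higher numbers for weaker inhibition:

Compound 1 `CCCCN(CC)Cc1c(C(F)(F)F)nc2n(-c3c(C)cc(C)cc3C)c(Cl)cn12` gives 78 nM.
Compound 2 `C=C(C)CN(CC)Cc1c(C(F)(F)F)nc2n(-c3c(C)cc(C)cc3C)c(Cl)cn12` gives 67 nM.
Compound 3 `CCN(Cc1c(C(F)(F)F)nc2n(-c3c(C)cc(C)cc3C)c(Cl)cn12)CC1CCC1` gives 16 nM.

Of these three, compound 3 stands lowest in this assay: the steps of a 4.9-fold lower number from compound 1 to compound 3 (0.69 log units; beyond the scatter) and a 4.2-fold lower number from compound 2 to compound 3 (0.62 log units; beyond the scatter) are both beyond the scatter, while the step of a 1.2-fold lower number from compound 1 to compound 2 (0.07 log units; within the scatter) is within it. So replacing a straight or branched chain on the amine side with a small ring is the one change so far that clearly strengthened binding.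

Compound 4 `CCCN(Cc1ccccc1)Cc1c(C(F)(F)F)nc2n(-c3c(C)cc(C)cc3C)c(Cl)cn12` has not been measured. It differs from compound 3 by benzyl(propyl)amino in place of (cyclobutylmethyl)(ethyl)amino on a saturated chain carbon bound to an aromatic carbon. Both substituents on that nitrogen change at once: the ethyl becomes propyl, and the cyclobutylmethyl becomes benzyl. For the measured compounds named here, none of the measured steps covers a benzyl group, and none lengthens the ethyl, so they bear only loosely on this change. What they do show is that the open chains of compound 1 and compound 2 sit well above compound 3, and compound 4 moves away from the ring that distinguished compound 3. The expected outcome is therefore a somewhat higher number, with wide uncertainty, as in the step of a 2.8-fold higher number from compound 3 to compound 4 (0.45 log units; beyond the scatter). Compound 4 is estimated to give 45 nM in this assay, with a range from 12 nM to 180 nM.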

Compound 4, inhibition constant: 170 nM
The estimate for compound 4 lay 3.8-fold (0.58 log units) below the measured number; the range from low to high includes it.
By their numbers in this assay, from the lowest: compound 3; then compounds 2 and 1 (each within the scatter of the next); then compound 4.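

In this assay, for the compounds shown here, benzyl(propyl)amino, on the saturated chain carbon bound to an aromatic carbon, is the only amine group here that gives a higher number than all the others, including the open-chain amines: there is a large step of an 11-fold higher number from compound 3 to compound 4 (1.03 log units; beyond the scatter) and modest steps of a 2.5-fold higher number from compound 2 to compound 4 (0.40 log units; beyond the scatter) and a 2.2-fold higher number from compound 1 to compound 4 (0.34 log units; beyond the scatter) on the same read-out. A ring on the amine side therefore does not bring a low number by itself, for compound 3, with a four-membered non-aromatic ring, stands lowest, while compound 4, with a six-membered aromatic ring, stands highest and is the weakest of the four. No supporting data are available to explain this difference.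

Both groups on the nitrogen change together, so the compounds shown cannot separate the effect of ethyl becoming propyl from that of cyclobutylmethyl becoming benzyl. Also open, going by these compounds, is how this assay would read for a benzyl group paired with the ethyl, or for a cyclohexylmethyl group, which has a saturated six-membered ring in place of the aromatic one.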